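Replacing a small group on compound 1 with two rings

The source may report more compounds than this note shows. Statements on the series, on what has been measured and on what is new or still open speak of the compounds shown alone.

Measured so far in a functional assay on MCF7 cells (Homo sapiens) for antiproliferative activity, read by MTT assay, with a stated time of 48 h; on this read-out higher numbers stand for weaker inhibition and lower numbers for stronger inhibition:
compound 1 `CC(=O)Oc1c(Br)cc(Br)cc1/C=C1\N=C(c2ccccc2)N(C(N)=S)NC1=O` gives 28500 nM
compound 2 `COc1ccc(C2=N/C(=C\c3cc(Br)cc(Br)c3OC(C)=O)C(=O)NN2C(N)=S)cc1OC` gives 13400 nM
compound 3 `COc1cc(C2=N/C(=C\c3cc(Br)cc(Br)c3OC(C)=O)C(=O)NN2C(N)=S)cc(OC)c1OC` gives 360 nM

Compound 1 has the highest number of the three, which makes it the weakest inhibitor of this small set. Compound 4 `CC(=O)Oc1c(Br)cc(Br)cc1/C=C1\N=C(c2ccccc2)N(c2ncc(-c3ccccc3)s2)NC1=O` keeps the core of compound 1 and differs in one place: a group of 11 heavy atoms (9 carbon, 1 nitrogen, 1 sulfur; one five-membered aromatic ring with 2 hetero atoms, one six-membered aromatic ring of carbon only) in place of a group of 3 heavy atoms (1 carbon, 1 nitrogen, 1 sulfur; no ring), on an amine nitrogen in a ring. The new group is 5-phenyl-1,3-thiazol-2-yl, and it sits on an amine nitrogen in a ring.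

Neither measured step touches that place. Putting 3,4-dimethoxyphenyl in place of phenyl gave a 2.1-fold lower number from compound 1 to compound 2 (0.33 log units; beyond the scatter), and one more methoxy in place of hydrogen gave a 37-fold lower number from compound 2 to compound 3 (1.57 log units; beyond the scatter). Both steps alter the phenyl group, which compound 4 leaves unchanged. They show that a single change can move the number a long way in this assay, but they do not give the direction of this one. Going by the values given here, no measured compound carries the new group, so the expectation is loose: a modest fall in the number, with a rise not ruled out. The estimated change is a 2.4-fold lower number from compound 1 to compound 4 (0.38 log units; beyond the scatter) in the expected direction. The value estimated for compound 4 is 12000 nM and the expected range runs from 2000 nM to 60000 nM as its limits.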

Compound 4, half-maximal inhibitory concentration: 38300 nM
Compound 4: middle estimate off by 3.2-fold (0.50 log units), on the low side; measured number inside the range.
By their numbers in this assay, from the lowest: compound 3; then compound 2; then compounds 1 and 4 (each within the scatter of the next).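

In this assay, putting 5-phenyl-1,3-thiazol-2-yl on the amine nitrogen in the ring gives a 1.3-fold higher number from compound 1 to compound 4 (0.13 log units; within the scatter), so the two numbers cannot be told apart. Going by these compounds alone, this is the first look at this position, and it shows that a group of 11 heavy atoms with two aromatic rings can take the place of a group of 3 heavy atoms with no ring without a measurable difference in this read-out, even though the count of hydrogen-bond donors on the group goes from 1 to 0. Nothing available here explains why the exchange leaves the two compounds indistinguishable in this assay.

Still open, on these data alone, is whether the new group would leave the number equally undisturbed on the background of compound 3, which gives 360 nM, since this single pair rests on the plain phenyl background of compound 1. As far as these compounds go, it is also open whether a different group on that ring nitrogen, such as a methyl, an acetyl or a chain ending in an amine, or a carboxylic acid on the new group's phenyl ring, would move the number at all.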